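Methyl for Nitro on the Chalcone Aryl Ring

A few compounds are considered here, and "the series" means these few. Any claim that something is new, unique, unknown or untested is made for them only; others in the source may bear on it.

Measured compounds:
Compound 1 `CNC(=O)c1cc(Oc2ccc(/C=C/C(=O)c3ccc([N+](=O)[O-])cc3)cc2)ccn1`: 54300 nM
Compound 2 `CNC(=O)c1cc(Oc2ccc(C(=O)/C=C/c3ccc(F)cc3Cl)cc2)ccn1`: 21100 nM
Compound 3 `CNC(=O)c1cc(Oc2ccc(C(=O)/C=C/c3cc(OC)c(OC)c(OC)c3)cc2)ccn1`: 3880 nM

In a functional assay on MCF7 cells (Homo sapiens) for cytotoxicity, read by MTT assay, with a stated time of 72 h (on this read-out higher numbers stand for weaker inhibition and lower numbers for stronger inhibition), compound 1 gives the highest of the three numbers; compound 2 sits lower by a step beyond the scatter, and compound 3 lies furthest below it. Compound 4 `CNC(=O)c1cc(Oc2ccc(/C=C/C(=O)c3ccc(C)cc3)cc2)ccn1` is not yet measured. It differs from compound 1 in one place: methyl in place of nitro on an aromatic carbon, so the 4-nitrophenyl becomes 4-methylphenyl. Within the data shown here, no measured pair shows this change directly, so the expectation rests on compound 1 alone. A modest step in the direction of lower numbers, from compound 1 to compound 4, is expected, a 1.6-fold lower number from compound 1 to compound 4 (0.19 log units; within the scatter), though it may stay within the scatter. Compound 4 is therefore estimated at 35000 nM, with a range from 10000 nM to 120000 nM.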

Compound 4, half-maximal inhibitory concentration: 24900 nM
Estimate against measurement, compound 4: 1.4-fold (0.15 log units) above; low and high end bracket the measured number.
By their numbers in this assay, from the lowest: compound 3; then compounds 2 and 4 (each within the scatter of the next); then compound 1.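

Among these compounds, the change from 4-nitrophenyl to 4-methylphenyl gives the first direct reading at this aromatic carbon, with a 2.2-fold lower number from compound 1 to compound 4 (0.34 log units; beyond the scatter). This single replacement on the core of compound 1 is enough to move the number beyond the usual scatter, so the group at this place matters, though the step is modest. No measured evidence bears on why the number moves.

From the compounds shown here alone, whether an amine or a carboxylic acid on the same carbon would move the number further remains open. With only nitro and methyl compared here, no trend across groups at this place can be drawn.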